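Sulfonyl in place of carbonyl on the anilide nitrogen

This account rests on a few compounds, and the source may have more. Where it says the series, first, only, none or still open, it means among the compounds named here.

Compound 2 `O=C(Nc1cccc(/C=C/C(=O)c2nc3ccccc3[nH]2)c1)c1cc(Cl)cc(Cl)c1` stands at the edge of what the assay reports: in a functional assay on MCF7 cells (Homo sapiens) for antiproliferative activity, read by MTT assay, with a stated time of 48 h (a lower number here means a stronger inhibitor, a higher number a weaker inhibitor), compound 2 gives only > 100000 nM, which is a limit and not a number. Among the measured compounds shown here, its one measured neighbour, compound 1 `Cc1ccc(C(=O)Nc2cccc(/C=C/C(=O)c3nc4ccccc4[nH]3)c2)cc1`, gives 9690 nM in this assay. The measured step between them is an at least 10-fold higher number from compound 1 to compound 2 (1.01 log units; beyond the scatter), and the evidence on that step is confined to the limit of > 100000 nM in this assay, at which 1 of the 2 values shown sits. Compound 3 `Cc1ccc(S(=O)(=O)Nc2cccc(/C=C/C(=O)c3nc4ccccc4[nH]3)c2)cc1` is not yet measured; it differs from compound 2 by (4-methylphenyl)sulfonyl in place of (3,5-dichlorophenyl)carbonyl on a nitrogen on an aromatic ring. For the measured compounds named here, the step from compound 1 to compound 2 bears on this change only in reverse, since the 4-methylphenyl group of compound 1 returns in compound 3, while carbonyl giving way to sulfonyl is covered by no measured pair. A move back toward the number of compound 1 is therefore expected, though with wide uncertainty. Compound 3 is expected to give 15000 nM (range 4000 nM to 100000 nM) in this assay. The expected step is an at least 6.6-fold lower number from compound 2 to compound 3 (0.82 log units; beyond the scatter).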

Compound 3, half-maximal inhibitory concentration: 3220 nM
For compound 3 the middle estimate is 4.7-fold (0.67 log units) above the measured one; the measured number lies below the stated range.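

Among the compounds shown here, with 4-methylphenyl held constant, sulfonyl in place of carbonyl on a nitrogen on an aromatic ring gives a 3.0-fold lower number from compound 1 to compound 3 (0.48 log units; beyond the scatter) in this assay, the first direct reading of this linker change. The larger step, an at least 31-fold lower number from compound 2 to compound 3 (1.49 log units; beyond the scatter), changes the linker and the attached phenyl group together, and compound 2 enters it only as a limit, so its true size remains unfixed: the limit of > 100000 nM in this assay, at which 1 of the 3 values shown sits. Compound 3 is the strongest of the three compounds in this assay, its steps to both others lying beyond the scatter.

Whether sulfonyl gives a similar shift with 3,5-dichlorophenyl attached remains open, as the compounds shown offer no such pair. Also open, from the compounds shown here alone, is how a methoxy group in place of the methyl on the phenyl ring of compound 3 would read.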